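Swapping One Aryl Group on a Cytotoxic Compound

This account rests on a few compounds, and the source may have more. Where it says the series, first, only, none or still open, it means among the compounds named here.

Among the compounds with values here, only two compounds have numbers so far. In a functional assay on HCT-15 cells (Homo sapiens) for cytotoxicity, in the presence of a further agent that is not named here (on this read-out lower numbers stand for stronger inhibition and higher numbers for weaker inhibition), compound 1 `Cc1ccccc1-c1cc(-c2ccc(Cl)o2)cc(-c2ccsc2)n1` gives 4630 nM as the lower of the two, while compound 2 `Cc1ccc(-c2cc(-c3ccc(Cl)o3)cc(-c3cccs3)n2)cc1` gives 9890 nM and stands higher by more than the usual scatter of repeated measurements. Compound 3 `Clc1cccc(-c2cc(-c3ccc(Cl)o3)cc(-c3ccsc3)n2)c1` has not been measured yet. It keeps the core of compound 1 but carries 3-chlorophenyl in place of 2-methylphenyl on an aromatic carbon, next to the ring nitrogen (3-chlorophenyl in place of 2-methylphenyl on an aromatic carbon). Within the data shown here, no measured pair here isolates a single change, so the data offer no direct guide to this swap, and no step beyond the scatter is expected in this assay for it. The expected step is a 1.2-fold lower number from compound 1 to compound 3 (0.06 log units; within the scatter) and it lies within the scatter. Compound 3 is estimated at 4000 nM with a likely range from 1500 nM to 11000 nM on this read-out.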

Compound 3, half-maximal inhibitory concentration: 13700 nM
Estimate against measurement, compound 3: 3.4-fold (0.53 log units) below; measured number above the stated range.
By their numbers in this assay, from the lowest: compound 1; then compounds 2 and 3 (each within the scatter of the next).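

Replacing 2-methylphenyl with 3-chlorophenyl on the aromatic carbon next to the ring nitrogen gives a 3.0-fold higher number from compound 1 to compound 3 (0.47 log units; beyond the scatter) in this assay, a modest step. This position is therefore sensitive to which substituted phenyl ring it carries, even though both groups are six-membered carbon rings with no hydrogen-bond donors or acceptors and no net charge. The swap changes both the substituent and its place on the phenyl ring, and nothing available here explains the step.

Still open, as far as these compounds go, is whether the substituent or its place on the ring matters more, a question that 2-chlorophenyl or 3-methylphenyl on the same core could help separate. Also open, from the compounds shown here alone, is how this position would respond to a group other than a substituted phenyl ring, such as an amine or a carboxylic acid.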